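Moving a Methyl Around the Piperidine Ring

The source may report more compounds than this note shows. Statements on the series, on what has been measured and on what is new or still open speak of the compounds shown alone.

Among the compounds with values here, compound 2 `CC1CCCN(CCCOc2ccc(-c3ccc(C#N)cc3)cc2)C1` holds the higher of the two numbers measured so far, though the gap to compound 1 lies within the usual scatter: in an assay on isolated protein for binding affinity to histamine H2 receptor (Homo sapiens) (on this read-out higher numbers stand for weaker inhibition and lower numbers for stronger inhibition), compound 2 gives 11700 nM, and compound 1 `N#Cc1ccc(-c2ccc(OCCCN3CCCNCC3)cc2)cc1` gives 7760 nM. Compound 3 `CC1CCN(CCCOc2ccc(-c3ccc(C#N)cc3)cc2)CC1` has the same atoms joined differently: 4-methylpiperidin-1-yl in place of 3-methylpiperidin-1-yl on a saturated chain carbon, three bonds along the chain from an oxygen on an aromatic ring. Within the data shown here, the only measured step, a 1.5-fold higher number from compound 1 to compound 2 (0.18 log units; within the scatter), exchanges a different ring and says nothing direct about where a methyl sits on the piperidine. For compound 3 no step beyond the scatter is expected, so its estimated value is 11000 nM, between 4000 nM and 30000 nM, a step of a 1.1-fold lower number from compound 2 to compound 3 (0.03 log units; within the scatter).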

Compound 3, inhibition constant: 9120 nM
The estimate for compound 3 lay 1.2-fold (0.08 log units) above the measured number; the range from low to high includes it.
By their numbers in this assay, from the lowest: compounds 1, 3 and 2 (each within the scatter of the next).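

Placing the methyl as in 4-methylpiperidin-1-yl rather than 3-methylpiperidin-1-yl gives a step within the scatter (a 1.3-fold lower number from compound 2 to compound 3 (0.11 log units; within the scatter)), so in this assay these two compounds cannot be told apart. Setting 4-methylpiperidin-1-yl in place of 1,4-diazepan-1-yl also stays within the scatter (a 1.2-fold higher number from compound 1 to compound 3 (0.07 log units; within the scatter)), so none of the three rings at this chain carbon stands apart from the others. Nothing at hand offers a reason for this result. Still open, from the compounds shown here alone, is whether a morpholine ring or an unsubstituted piperidine at this place would give a step beyond the scatter.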